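The source may report more compounds than this note shows. Statements on the series, on what has been measured and on what is new or still open speak of the compounds shown alone.

Measured so far in a functional assay on M14 cells (Homo sapiens) for antiproliferative activity, read by sulforhodamine B assay, with a stated time of 48 h; a lower number here means a stronger inhibitor of growth, a higher number a weaker inhibitor of growth:

compound 1 : `Cc1nc(SCC(=O)Nc2nc(-c3ccc(Cl)cc3)cs2)n(Nc2ccccc2)c1C`, 3690 nM
compound 2 : `Cc1ccc(Nn2c(SCC(=O)Nc3nc(-c4ccccc4)cs3)nc(C)c2C)cc1`, 3700 nM

The two numbers sit within the scatter of each other, so compound 1 cannot be separated from compound 2 on this assay; both belong to the same shared core carrying a thioacetamide link to a thiazole and an anilino group on the ring nitrogen, and neither stands apart. Within the data shown here, no pair of measured compounds differs in a single place, so no measured step is available to lean on.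

Compound 3 is `COc1ccc(Nn2c(SCC(=O)Nc3nc(-c4ccc(Cl)cc4)cs3)nc(C)c2C)cc1`. It differs from compound 1 by methoxy in place of hydrogen on an aromatic carbon. The methoxy adds one hydrogen-bond acceptor and two heavy atoms at the far end of the anilino group, a region that compound 2 shows tolerates a small substituent without any shift beyond the scatter. With nothing else to go on, the expected step from compound 1 to compound 3, a 1.1-fold lower number from compound 1 to compound 3 (0.02 log units; within the scatter), is none beyond the scatter in either direction. Compound 3 is therefore expected to give 3500 nM in this assay, with a range from 1500 nM to 8500 nM.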

Compound 3, concentration for 50% growth inhibition: 3020 nM
Compound 3: the middle estimate sits 1.2-fold (0.06 log units) above what was measured; the measured number falls inside the stated range.
By their numbers in this assay, from the lowest: compounds 3, 1 and 2 (each within the scatter of the next).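

In this assay, the change from anilino to (4-methoxyphenyl)amino gives the series its first reading of a single change, on an aromatic carbon para to a large group: a 1.2-fold lower number from compound 1 to compound 3 (0.09 log units; within the scatter). Methoxy in place of hydrogen at this carbon therefore does not separate compound 3 from compound 1 on this read-out, so the position accepts this group without a measurable shift in growth inhibition. Compound 2 differs from compound 1 in more than one place and could not give this reading, and no further data bear on why the step is this small.

As far as these compounds go, one group at one carbon says little about how far this tolerance extends, and whether a longer chain such as butoxy, a basic amine or a carboxylic acid on the same carbon would also leave the number within the scatter remains open. The compounds shown also leave the other parts of the shared core without a single-change reading, including the thioacetamide link and the two methyl groups, so the contribution of each part to growth inhibition cannot yet be stated.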